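Moving the trifluoromethyl on the hydrazone aryl ring

The compounds below may be only part of what the source reports. "The series", "measured", "known", "first", "only" and "open" are said of these compounds alone.

Measured so far:
compound 1 `CN(C(=O)NC(=O)c1cccc(C(F)(F)F)c1)c1nc(C(F)(F)F)c(C(=O)N/N=C/c2cccc(C(F)(F)F)c2)s1`, 5.79 ug/mL
compound 2 `CN(C(=O)NC(=O)c1ccc([N+](=O)[O-])cc1)c1nc(C(F)(F)F)c(C(=O)N/N=C/c2cccc(C(F)(F)F)c2)s1`, 4.73 ug/mL
compound 3 `Cc1nc(N(C)C(=O)NC(=O)c2c(F)cccc2F)sc1C(=O)N/N=C/c1ccccc1F`, > 100 ug/mL

In a functional assay on HepG2 cells (Homo sapiens) for inhibition, read by MTT assay, with a stated time of 72 h (on this read-out higher numbers stand for weaker inhibition and lower numbers for stronger inhibition), compound 1 gives 5.79 ug/mL and compound 2 gives 4.73 ug/mL; the two numbers are the only ones shown, and a 1.2-fold lower number from compound 1 to compound 2 (0.09 log units; within the scatter), so they lie within the scatter of each other. Compound 3 reaches only the limit of this assay, > 100 ug/mL.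

Compound 4 `CN(C(=O)NC(=O)c1cccc(C(F)(F)F)c1)c1nc(C(F)(F)F)c(C(=O)N/N=C/c2ccccc2C(F)(F)F)s1` differs from compound 1 by 2-(trifluoromethyl)phenyl in place of 3-(trifluoromethyl)phenyl on a carbon with a double bond to nitrogen. For the measured compounds named here, the single measured step, a 1.2-fold lower number from compound 1 to compound 2 (0.09 log units; within the scatter), touches the group on the carbonyl carbon, not the group on the carbon with a double bond to nitrogen, and was within the scatter; no measured pair informs the change to compound 4. Going by the values given here, with no step to lean on, no movement beyond the scatter is expected. Compound 4 is estimated at 6 ug/mL in this assay, with a range from 3 ug/mL to 12 ug/mL. The expected step is a 1.0-fold higher number from compound 1 to compound 4 (0.02 log units; within the scatter).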

Compound 4, half-maximal inhibitory concentration: 10.4 ug/mL
For compound 4 the middle estimate is 1.7-fold (0.24 log units) below the measured one; low and high end bracket the measured number.
By their numbers in this assay, from the lowest: compounds 2, 1 and 4 (each within the scatter of the next, the first and the last beyond it). At a limit, above all of these: compound 3.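

In this assay, 2-(trifluoromethyl)phenyl in place of 3-(trifluoromethyl)phenyl on a carbon with a double bond to nitrogen gives a 1.8-fold higher number from compound 1 to compound 4 (0.25 log units; within the scatter). For the compounds shown here, this is the first measured pair at this position, and it shows that the two trifluoromethyl isomers cannot be told apart here. No measurement shown bears on a cause for this step.

Still open, on these data alone, is whether a phenyl carrying a carboxylic acid or an amine in place of trifluoromethyl at this carbon stays within the scatter of compound 1.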